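A few compounds are considered here, and "the series" means these few. Any claim that something is new, unique, unknown or untested is made for them only; others in the source may bear on it.

Of the compounds shown here, three built on one shared core have been tested in a functional assay on MDA-MB-231 cells (Homo sapiens) for inhibition, read by sulforhodamine B assay, with a stated time of 48 h; on this read-out lower numbers stand for stronger inhibition of growth and higher numbers for weaker inhibition of growth. Compound 1 `O=C(Nc1cccc(-n2cc(-c3ccncc3)c(-c3ccc(Cl)c(O)c3)n2)c1)Nc1cccc(C(F)(F)F)c1` gives 26800 nM, the highest of the three numbers and so the weakest growth inhibitor among them. Compound 2 `O=C(Nc1cccc(-n2cc(-c3ccncc3)c(-c3ccc(Cl)c(O)c3)n2)c1)Nc1ccc(Cl)c(Cl)c1` gives 8330 nM, and compound 3 `COc1cc(-c2nn(-c3cccc(NC(=O)Nc4cccc(C(F)(F)F)c4)c3)cc2-c2ccncc2)ccc1Cl` gives 2370 nM. Two changes starting from compound 1 have been measured: a 3.2-fold lower number from compound 1 to compound 2 (0.51 log units; beyond the scatter), and an 11-fold lower number from compound 1 to compound 3 (1.05 log units; beyond the scatter). Compound 4 `O=C(Nc1cccc(-n2cc(-c3ccncc3)c(-c3ccc(Cl)c(O)c3)n2)c1)Nc1cc(C(F)(F)F)cc(C(F)(F)F)c1` has not yet been measured; it differs from compound 1 by trifluoromethyl in place of hydrogen on an aromatic carbon. For the measured compounds named here, of the two measured steps, only the one to compound 2 alters the same six-membered aromatic ring of carbon only on the amide-type nitrogen, and that change brought a modest drop in the number; the step to compound 3 alters a different part of the molecule and offers no direct guide. A modest lowering of the number in this assay is therefore expected for compound 4, as a step of a 2.2-fold lower number from compound 1 to compound 4 (0.35 log units; beyond the scatter). Compound 4 is estimated at 12000 nM, with a range from 4000 nM to 32000 nM.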

Compound 4, concentration for total growth inhibition: 1660 nM
The estimate for compound 4 lay 7.2-fold (0.86 log units) above the measured number; the measured number lies below the stated range.
By their numbers in this assay, from the lowest: compounds 4 and 3 (each within the scatter of the next); then compound 2; then compound 1.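

Placing a trifluoromethyl group on this aromatic carbon, meta to the existing trifluoromethyl group, gives a large step in this assay, a 16-fold lower number from compound 1 to compound 4 (1.21 log units; beyond the scatter), with the free hydroxyl of compound 1 left in place. For the compounds shown here, the only earlier change on this same ring was modest, a 3.2-fold lower number from compound 1 to compound 2 (0.51 log units; beyond the scatter), so compound 4 shows that this ring can shift the read-out much further than that first step suggested. No measurement on hand explains why this one added group has so large an effect.

From the compounds shown here alone, whether the step depends on trifluoromethyl itself stays open, since a nitrile, an amine or a carboxylic acid on this same carbon could behave quite differently. Also open, going by these compounds, is whether this addition would lower the number further on the methyl ether of compound 3.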